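The source may hold more compounds than are shown below. What is called first, only, known or untested is meant among the compounds shown, and "the series" means these compounds.

Three compounds on one shared core have been followed in a physicochemical assay for metabolic stability, read by HPLC and mass spectrometry, in phosphate buffer, at 37 degrees C, at pH 7.4; a higher number here means that the compound lasts longer, a lower number that the compound disappears faster. Compound 1 `CC(C)(O/N=C(\C(=O)N[C@@H]1C(=O)N(S(=O)(=O)O)[C@@H]1Cn1ccnn1)c1csc(N)n1)C(=O)O`, which carries a five-membered aromatic ring, gives a half-life of 257 h. Compound 2 `CC(C)(O/N=C(\C(=O)N[C@@H]1C(=O)N(S(=O)(=O)O)[C@@H]1CN1C[C@@H](CN)OC1=O)c1csc(N)n1)C(=O)O` gives > 37 h, which is a limit and not a number. Compound 3 `CC(C)(O/N=C(\C(=O)N[C@@H]1C(=O)N(S(=O)(=O)O)[C@@H]1CN1C[C@@H](CNC(=N)N)OC1=O)c1csc(N)n1)C(=O)O` gives > 37 h, which is likewise a limit. Compound 3 therefore has no reading of its own and stands on (the limit of > 37 h in this assay, at which 2 of the 3 values shown sit).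

Compound 4 `CC(C)(O/N=C(\C(=O)N[C@@H]1C(=O)N(S(=O)(=O)O)[C@@H]1CN1C[C@H](CNC(=N)N)OC1=O)c1csc(N)n1)C(=O)O` has not yet been measured. Its difference from compound 3 is this: the two compounds have the same atoms and bonds; at least one stereo element is drawn with a configuration in one of them and without one in the other: 1 of 5 stereo elements differ; a stereocentre at a saturated ring carbon is drawn R in compound 3 and S in compound 4. The atoms and bonds stay the same, and only the configuration at that saturated ring carbon changes.

The measured steps offer little guidance. They are a step that the limit leaves unreadable from compound 1 to compound 2, a step that the limit leaves unreadable from compound 1 to compound 3 and a step that the two limits leave unreadable from compound 2 to compound 3. None has a readable size, and each exchanges a group rather than a single stereocentre. For the measured compounds named here, no measured step therefore supports a change beyond the usual scatter, and no direction is favoured. The expected step is a step that the limit leaves unreadable from compound 3 to compound 4, which is no more than scatter. In this assay the estimated half-life of compound 4 is 100 h, with an expected range from 40 h to 300 h, and the assay may well report only a limit again.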

Compound 4, half-life: > 37 h
Compound 4: a limit, no number (the forecaster's own chance of this, stated with the estimate: 75%); the middle value lies beyond the limit too.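

In this assay compound 4 gives > 37 h, which is a limit and not a number. For the compounds shown here, no step from compound 1, compound 2 or compound 3 to compound 4 can be read. The compounds shown leave open whether the configuration at the saturated ring carbon, drawn R in compound 3 and S in compound 4, changes the half-life at all.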